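A few compounds are considered here, and "the series" means these few. Any claim that something is new, unique, unknown or untested is made for them only; others in the source may bear on it.

Compound 1 `Cc1cc(C)nc(Oc2ccc(NC(=O)Nc3ccc(OC(F)(F)F)cc3)cc2)n1` and compound 2 `Cc1cc(C)nc(Oc2ccc(NC(=O)Nc3ccc(F)cc3)cc2)n1` share one core and differ by fluoro in place of trifluoromethoxy on an aromatic carbon. In a functional assay on MGC-803 cells (Homo sapiens) for cytotoxicity, read by MTT assay, with a stated time of 3 days (on this read-out higher numbers stand for weaker inhibition and lower numbers for stronger inhibition), compound 1 gives > 50000 nM, which is a limit of the assay and not a number. Compound 2 in this assay gives > 50000 nM, also a limit. The change therefore produced a step that the two limits leave unreadable from compound 1 to compound 2 because both values sit at the limit of > 50000 nM in this assay, at which 2 of the 3 values shown sit.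

Compound 3 `Cc1cc(C)nc(Sc2ccc(NC(=O)Nc3ccc(OC(F)(F)F)cc3)cc2)n1` differs from compound 1 by (4,6-dimethylpyrimidin-2-yl)sulfanyl in place of (4,6-dimethylpyrimidin-2-yl)oxy on an aromatic carbon. In this assay, within the data shown here, compound 3 gives 13800 nM, the only number among the three, which amounts to an at least 3.6-fold lower number from compound 1 to compound 3 (0.55 log units; beyond the scatter).

Compound 4 `Cc1cc(C)nc(Sc2ccc(NC(=O)Nc3ccc(F)cc3)cc2)n1` applies the same change on the core of compound 3, (fluoro in place of trifluoromethoxy on an aromatic carbon), at a place described in the same words. With the earlier step unreadable, the expected step is a 2.2-fold higher number from compound 3 to compound 4 (0.34 log units; beyond the scatter), a guarded guess with a real chance of a limit only. Compound 4 is estimated at 30000 nM, between 10000 nM and 90000 nM.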

Compound 4, half-maximal inhibitory concentration: > 50000 nM
Compound 4 gave a limit, no number; the forecaster's own chance of this, stated with the estimate: 45%; at least 1.6-fold (0.22 log units) between middle value and limit.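

In this assay, fluoro in place of trifluoromethoxy on the core of compound 3 gives an at least 3.6-fold higher number from compound 3 to compound 4 (0.55 log units; beyond the scatter). Compound 4 gives > 50000 nM, which is a limit of the assay and not a number, so the size of this step is only a minimum. The same change on the core of compound 1 cannot be read, so the series does not show whether the change has the same size on both cores: the limit of > 50000 nM in this assay, at which 3 of the 4 values shown sit.

The compounds shown leave open how an amine or a carboxylic acid in place of trifluoromethoxy would read on the core of compound 3. They also leave open whether a longer chain there would give a number in this assay.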